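Replacing the Piperazine Group of Compound 3

The source may report more compounds than this note shows. Statements on the series, on what has been measured and on what is new or still open speak of the compounds shown alone.

Of the compounds shown here, three sharing one core have been measured in a functional assay on PC-3 cells (Homo sapiens) for inhibition, read by MTT assay, with a stated time of 48 h, tested at 10 uM; a lower number here means less inhibition of growth, a higher number more inhibition of growth at the concentration tested. Compound 1 `CCN(CC)Cc1c(O)c([C@H]2CCN(C)C[C@H]2O)c2oc(C)cc(=O)c2c1O` gives 2%, compound 2 `Cc1cc(=O)c2c(O)c(CN3CCCC3CO)c(O)c([C@H]3CCN(C)C[C@H]3O)c2o1` gives 15%, and compound 3 `CCOC(=O)N1CCN(Cc2c(O)c([C@H]3CCN(C)C[C@H]3O)c3oc(C)cc(=O)c3c2O)CC1` gives 1%. Compound 3 stands level with compound 1, with a number 1 percentage points lower from compound 1 to compound 3 (within the scatter). Only compound 2 separates from it, with a number 14 percentage points lower from compound 2 to compound 3 (beyond the scatter).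

The untested compound 4 `Cc1cc(=O)c2c(O)c(CN(C(C)C)C(C)C)c(O)c([C@H]3CCN(C)C[C@H]3O)c2o1` has diisopropylamino in place of 4-(ethoxycarbonyl)piperazin-1-yl on a saturated chain carbon bound to an aromatic carbon. All three measured steps involve this same place. The entering group is an open-chain amine, the nearest match to the diethylamino of compound 1, and the change between those two groups gave a number 1 percentage points lower from compound 1 to compound 3 (within the scatter). The only clear movement came with the 2-(hydroxymethyl)pyrrolidin-1-yl of compound 2, with a number 13 percentage points higher from compound 1 to compound 2 (beyond the scatter), and compound 4 does not carry that group.

In this assay, the expected result is no change beyond the scatter, with an estimated a number 3 percentage points higher from compound 3 to compound 4 (within the scatter). Compound 4 is expected to give about 4%, within an estimated range of 0% to 15%.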

Compound 4, percent growth inhibition at one concentration: 0%
For compound 4 the middle estimate is 4 percentage points above the measured one; measured number inside the range.
By their numbers in this assay, from the lowest: compounds 4, 3 and 1 (each within the scatter of the next); then compound 2.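

In this assay, diisopropylamino joins the groups that leave the number flat on this saturated chain carbon bound to an aromatic carbon, with a number 1 percentage points lower from compound 3 to compound 4 (within the scatter) and, against the other open-chain amine, a number 2 percentage points lower from compound 1 to compound 4 (within the scatter). For the compounds shown here, three quite different amines, two without a ring and one a piperazine, therefore sit level, while 2-(hydroxymethyl)pyrrolidin-1-yl remains the only group that separates, with a number 15 percentage points lower from compound 2 to compound 4 (beyond the scatter). No measurement available here explains why that one group stands apart.

On these data alone, it remains open whether the higher number of compound 2 goes with its pyrrolidine ring or with its hydroxymethyl group: plain pyrrolidin-1-yl and an open-chain amine bearing a 2-hydroxyethyl group would pull those two apart. A single concentration also leaves open how these compounds would compare at higher doses.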